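The compounds below may be only part of what the source reports. "The series", "measured", "known", "first", "only" and "open" are said of these compounds alone.

In an ADME assay on the whole organism (Mus musculus, strain Swiss Webster) for pharmacokinetics, read by LC-MS, at a dose of 50 mg/kg by the oral route (on this read-out lower numbers stand for lower exposure and higher numbers for higher exposure at the dose given), compound 3 (`O=C(Nc1ccc(F)c(-c2nc3ncc(-c4cccc(F)c4)cc3[nH]2)c1)N1CCCC1`) gives 15000 ng.h/mL, compound 1 (`O=C(Nc1ccc(F)c(-c2nc3ncc(-c4ccc(F)cc4)cc3[nH]2)c1)N1CCCC1`) gives 10200 ng.h/mL and compound 2 (`O=C(Nc1ccc(F)c(-c2nc3ncc(-c4cccc(F)c4F)cc3[nH]2)c1)N1CCCC1`) gives 4750 ng.h/mL. The two monofluorinated compounds are not separated, with a 1.5-fold higher number from compound 1 to compound 3 (0.17 log units; within the scatter). Compound 3 stands clear of the difluorinated compound, with a 3.2-fold higher number from compound 2 to compound 3 (0.50 log units; beyond the scatter).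

Compound 4 (`O=C(Nc1ccc(F)c(-c2nc3ncc(-c4ccccc4F)cc3[nH]2)c1)N1CCCC1`) carries 2-fluorophenyl in place of 3-fluorophenyl on an aromatic carbon. Going by the values given here, two measured steps bear on this change. Exchanging one monofluorophenyl group for another gave only a 1.5-fold higher number from compound 1 to compound 3 (0.17 log units; within the scatter), which argues against a large step. Among the compounds with values here, the 2,3-difluorophenyl group of compound 2 is the only measured group that shares the 2-fluoro pattern, and it came with a 2.1-fold lower number from compound 1 to compound 2 (0.33 log units; beyond the scatter). Within the data shown here, no measured compound isolates that pattern, so the direction rests on compound 2 alone. A small to modest fall is therefore expected, and the estimated step is a 1.7-fold lower number from compound 3 to compound 4 (0.22 log units; within the scatter). For compound 4, the expected value is 9000 ng.h/mL, with an estimated range of 4000 ng.h/mL to 18000 ng.h/mL.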

Compound 4, area under the concentration-time curve: 4870 ng.h/mL
Beside the measured number, compound 4's estimate is 1.8-fold (0.27 log units) above it; low and high end bracket the measured number.
By their numbers in this assay, from the lowest: compounds 2 and 4 (each within the scatter of the next); then compounds 1 and 3 (each within the scatter of the next).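

In this assay, the place of the single fluoro on this phenyl group can matter: 2-fluorophenyl in place of 3-fluorophenyl gives a step beyond the scatter (a 3.1-fold lower number from compound 3 to compound 4 (0.49 log units; beyond the scatter)), and the same holds for 2-fluorophenyl in place of 4-fluorophenyl (a 2.1-fold lower number from compound 1 to compound 4 (0.32 log units; beyond the scatter)). Hydrogen in place of the second fluoro of the 2,3-difluorophenyl group leaves the number within the scatter (a 1.0-fold higher number from compound 2 to compound 4 (0.01 log units; within the scatter)), so across these four compounds, the two with a 2-fluoro pattern sit together, clear of the two without it, and no compound here goes against this. No measurement shown gives a reason for this difference.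

On these data alone, whether the pattern is specific to fluoro stays open, as 2-chlorophenyl, 2-methoxyphenyl and unsubstituted phenyl would test it. Also open, as far as these compounds go, is whether the gap reflects absorption or clearance, as a single exposure number cannot separate them.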